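Notes on the aryl ether series and compound 4

A few compounds are considered here, and "the series" means these few. Any claim that something is new, unique, unknown or untested is made for them only; others in the source may bear on it.

Compound 1 `Cc1nc(O)c2cc(-c3ccc(Cl)c(OCC(=O)O)c3)c(C(C)C)cc2n1` carries a carboxymethoxy group on the chlorophenyl ring. In a functional assay for inhibition of transient receptor potential cation channel subfamily V member 1 (Homo sapiens), read by fluorescence and calcium flux (a lower number here means a stronger inhibitor, a higher number a weaker inhibitor), compound 1 reaches only a limit, > 1000 nM, and so stands without a number. Compound 2 `CCc1nc(O)c2cc(-c3ccc(Cl)cc3)c(C(C)C)cc2n1` likewise gives only a limit, > 1000 nM. Compound 3 `CCCCOc1cc(-c2cc3c(O)nc(C)nc3cc2C(C)C)ccc1Cl`, the butoxy analogue, gives 82 nM in this assay. For the measured compounds named here, the one measured step that bears on the change under study is an at least 12-fold lower number from compound 1 to compound 3 (1.08 log units; beyond the scatter); note that this step starts from the limit of > 1000 nM in this assay, at which 2 of the 3 values shown sit, so its true size is not fixed. Compound 4 `Cc1nc(O)c2cc(-c3ccc(Cl)c(OCC4CCC4)c3)c(C(C)C)cc2n1` differs from compound 1 by cyclobutyl in place of carboxy on a saturated chain carbon bound to an oxygen on an aromatic ring. As with the step to compound 3, the acid is removed and a carbon chain of comparable size takes its place, so a step of similar direction and magnitude is expected: an at least 10-fold lower number from compound 1 to compound 4 (1.00 log units; beyond the scatter) is the estimate, which would place compound 4 close to compound 3. The expected value for compound 4 is therefore 100 nM, within 30 nM to 400 nM.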

Compound 4, half-maximal inhibitory concentration: 144 nM
Estimate against measurement, compound 4: 1.4-fold (0.16 log units) below; the range from low to high includes it.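

In this assay, a second replacement of carboxy on a saturated chain carbon bound to an oxygen on an aromatic ring gives an at least 6.9-fold lower number from compound 1 to compound 4 (0.84 log units; beyond the scatter), so the gain seen with propyl is not confined to that one group. Cyclobutyl in place of propyl gives a 1.8-fold higher number from compound 3 to compound 4 (0.24 log units; within the scatter), so this assay does not separate the open chain from the four-membered ring at this place. The size of the step away from carboxy remains unfixed, as it starts from a limit: the limit of > 1000 nM in this assay, at which 2 of the 4 values shown sit.

Open, from the compounds shown here alone, is whether the same place tolerates an amine or a primary amide on that chain carbon, in place of the carbon-only groups. A longer chain, or a larger ring such as cyclohexyl, would show how far this tolerance extends.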